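Fluoro for methyl on two related cores

This account rests on a few compounds, and the source may have more. Where it says the series, first, only, none or still open, it means among the compounds named here.

Two pairs of compounds share one structural change. Compound 1 `COc1cc2c(Oc3ccc(NC(=O)c4cc(-c5ccc(C)cc5)ccn4)cc3F)ccnc2cc1OCCCN1CCCC1` and compound 2 `COc1cc2c(Oc3ccc(NC(=O)c4cc(-c5ccc(F)cc5)ccn4)cc3F)ccnc2cc1OCCCN1CCCC1` are both measured in a functional assay on A549 cells (Homo sapiens) for cytotoxicity, read by MTT assay, with a stated time of 72 h; a lower number here means a stronger inhibitor, a higher number a weaker inhibitor: compound 1 gives 1060 nM, and compound 2 gives 1800 nM. The step of a 1.7-fold higher number from compound 1 to compound 2 (0.23 log units; within the scatter) corresponds to the change fluoro in place of methyl on an aromatic carbon on the core of compound 1.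

Compound 3 `COc1cc2c(Oc3ccc(NC(=O)c4nccc(-c5ccc(C)cc5)n4)cc3F)ccnc2cc1OCCCN1CCN(C)CC1` carries a different core; how this core differs from that of compound 1 is not broken down here. In this assay compound 3 gives "not determined" (no result reported), so no single number is at hand for it. Compound 4 `COc1cc2c(Oc3ccc(NC(=O)c4nccc(-c5ccc(F)cc5)n4)cc3F)ccnc2cc1OCCCN1CCN(C)CC1` differs from compound 3 by fluoro in place of methyl on an aromatic carbon, which is the same change as that made between compound 1 and compound 2, on the same kind of place, and it occurs twice among these four compounds.

Since compound 3 has no value in this assay, the expectation for compound 4 cannot rest on a step from compound 3; it rests only on the values of compound 1 and compound 2 and on the step between them, which lay within the scatter. Compound 4 is therefore estimated at 1800 nM in this assay, with a wide expected range from 400 nM to 8000 nM. The cores of compound 1 and compound 2 and that of compound 4 are not the same, and no anchor for the second core is at hand.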

Compound 4, half-maximal inhibitory concentration: 680 nM
Compound 4: middle estimate off by 2.6-fold (0.42 log units), on the high side, within the range that was stated.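

With no single number for compound 3 in this assay, no step can be read from compound 3 to compound 4, although compound 4 gives 680 nM. The compounds shown leave open whether fluoro in place of methyl shifts the value on the core of compound 4 as it does on the core of compound 1. Nothing at hand bears on this result.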